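Three Compounds at the Limit, a Fourth Awaits

The compounds below may be only part of what the source reports. "The series", "measured", "known", "first", "only" and "open" are said of these compounds alone.

compound 1 `COc1ccc(-c2cc3ccccc3c(-c3ccc(O)cc3)n2)cc1`: > 50000 nM
compound 2 `COc1cc(OC)cc(-c2cc3ccccc3c(-c3cccc(OC)c3)n2)c1`: > 50000 nM
compound 3 `COc1cccc(-c2nc(-c3ccc(OC)c(OC)c3)cc3cc(C)ccc23)c1`: > 50000 nM

In a functional assay on DU-145 cells (Homo sapiens) for cytotoxicity, read by CCK-8 assay and cell counting, with a stated time of 72 h (a higher number here means a weaker inhibitor, a lower number a stronger inhibitor), compound 1 gives > 50000 nM, which is a limit of the assay and not a number. Compound 2 likewise reaches only the limit > 50000 nM. Compound 3 too sits at the limit > 50000 nM. Compound 3 therefore stands level with the others, all three sharing (the limit of > 50000 nM in this assay, at which 3 of the 3 values shown sit). Compound 4 `COc1ccc(-c2cc3cc(C)ccc3c(-c3ccc(O)cc3)n2)cc1OC` differs from compound 3 by 4-hydroxyphenyl in place of 3-methoxyphenyl on an aromatic carbon. For the measured compounds named here, no step between measured compounds is known here. Compound 1, which already carries a 4-hydroxyphenyl group, gave only > 50000 nM. For compound 4 the expected step of a number no higher from compound 3 to compound 4 (the limit leaves the size open) is none beyond the scatter, and the estimated value is 50000 nM, within 20000 nM to 100000 nM.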

Compound 4, half-maximal inhibitory concentration: 5980 nM
Estimate against measurement, compound 4: 8.4-fold (0.92 log units) above; the whole stated range lies above it.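

In this assay, 4-hydroxyphenyl in place of 3-methoxyphenyl, next to the ring nitrogen, gives an at least 8.3-fold lower number from compound 3 to compound 4 (0.92 log units; beyond the scatter). This makes compound 4 the only compound shown with a number rather than a limit, so a change at this position can move the read-out into the measurable range. The true size of the step stays unknown, as its starting point is a limit: the limit of > 50000 nM in this assay, at which 3 of the 4 values shown sit.

Going by these compounds, whether the hydroxy group or its place on the phenyl ring carries the step remains open. So does what an amine or a carboxylic acid would do on that ring.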